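A few compounds are considered here, and "the series" means these few. Any claim that something is new, unique, unknown or untested is made for them only; others in the source may bear on it.

Compound 2 `Cc1ccc(C(=O)N/N=C/c2cccc(Cl)c2)c(O)c1` gives 636000 nM in an ADME assay on cells (Mus musculus, strain BALB/C) for cytotoxicity, read by MTT assay, with a stated time of 24 h (a higher number here means that more compound is tolerated, a lower number that less compound is tolerated), a number that, although the largest of the three recorded, stands level within the scatter with compound 3 `Cc1ccc(C(=O)N/N=C/c2cc(Cl)ccc2O)c(O)c1`, which gives 560000 nM, and with compound 1 `Cc1ccc(C(=O)N/N=C/c2ccccc2F)c(O)c1`, which gives 362000 nM. Going by the values given here, the only measured step, a 1.1-fold lower number from compound 2 to compound 3 (0.06 log units; within the scatter), concerns a hydroxy in place of hydrogen and so says nothing directly about exchanging one halogen for another. Compound 4 `Cc1ccc(C(=O)N/N=C/c2cccc(Br)c2)c(O)c1` differs from compound 2 by bromo in place of chloro on an aromatic carbon. Among the compounds with values here, no measured step bears on this change, and the three known values sit close together, so the chemist expects no step beyond the scatter in this assay. The expected step is no change at the digits printed from compound 2 to compound 4 (within the scatter), giving an estimate for compound 4 of 636000 nM, with a range from 350000 nM to 1100000 nM.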

Compound 4, half-maximal cytotoxic concentration: 113000 nM
Estimate against measurement, compound 4: 5.6-fold (0.75 log units) above; measured number outside the range, below it.
By their numbers in this assay, from the lowest: compound 4; then compounds 1, 3 and 2 (each within the scatter of the next).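

In this assay, the identity of the halogen at this place, meta to a large group, turns out to matter: bromo in place of chloro gives a 5.6-fold lower number from compound 2 to compound 4 (0.75 log units; beyond the scatter), the only step beyond the scatter among those shown. Going by these compounds alone, the hydroxy change, a 1.1-fold lower number from compound 2 to compound 3 (0.06 log units; within the scatter), had revealed no such sensitivity, so the exchange of one halogen for another carries more weight here than the earlier compounds suggested. No evidence at hand accounts for this step.

On these data alone, whether iodo or an amine at this same place would stand with chloro or with bromo remains open. So does whether bromo in place of chloro gives a similar step on another aromatic carbon of this ring.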